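From Methyl to Ethyl, Starting at a Limit

The compounds below may be only part of what the source reports. "The series", "measured", "known", "first", "only" and "open" are said of these compounds alone.

Measured so far in a functional assay on the whole organism (strain BALB/c) with Mus musculus as the target, with a stated time of 4 h; a higher number here means that more compound is needed for the effect, a lower number that less compound is needed:
- compound 1 `CC1=C(CN2CC(C(=O)O)C2)CCc2cc(OCc3ccc4ccccc4c3)ccc21`: "not determined" (no result reported)
- compound 2 `CC1=C(CN2CC(C(=O)O)C2)CCc2cc(OCC3CCc4ccccc4C3)ccc21`: "not determined" (no result reported)
- compound 3 `COc1cc(C)ccc1COc1ccc2c(c1)CCC(CN1CC(C(=O)O)C1)=C2C`: > 0.1 mg/kg

Only compound 3 has a reading in this assay, since compound 1 and compound 2 have no reported result. Compound 3 sits at the limit of > 0.1 mg/kg in this assay, at which 1 of the 3 values shown sits. On these data alone, this reading is a limit of the assay and not a number, so its true value remains unknown.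

The next compound to be tested is compound 4 `CCc1ccc(COc2ccc3c(c2)CCC(CN2CC(C(=O)O)C2)=C3C)c(OC)c1`, which differs from compound 3 in one place: methyl in place of hydrogen on a saturated chain carbon bound to an aromatic carbon. Methyl takes the place of hydrogen on a saturated chain carbon bound to an aromatic carbon. Methyl thus becomes ethyl, and 2-methoxy-4-methylphenyl becomes 4-ethyl-2-methoxyphenyl.

Within the data shown here, no pair of measured compounds shows what a change of this kind does, so the data offer no guide to its direction. The expectation is therefore no shift beyond the usual scatter, and the estimate stays close to the only available reference point. That reference is compound 3 at > 0.1 mg/kg, again a limit. The estimated change is a step that the limit leaves unreadable from compound 3 to compound 4. Compound 4 may also return only a limit. For compound 4 the estimated value is 0.15 mg/kg, with an expected range from 0.04 mg/kg to 0.6 mg/kg.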

Compound 4, dose for half-maximal effect: 0.026 mg/kg
The estimate for compound 4 lay 5.8-fold (0.76 log units) above the measured number; measured number below the stated range.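

Adding one carbon at this place, so that methyl becomes ethyl and 2-methoxy-4-methylphenyl becomes 4-ethyl-2-methoxyphenyl, goes with an at least 3.8-fold lower number from compound 3 to compound 4 (0.58 log units; beyond the scatter) in this assay. Compound 3 has only a limit, not a number: the limit of > 0.1 mg/kg in this assay, at which 1 of the 4 values shown sits. The size of this step is therefore a minimum and the true gap may be larger, but its direction is clear: this small change on a saturated chain carbon bound to an aromatic carbon lowers the dose needed, and compound 4, at 0.026 mg/kg, gives this series its first actual number in this test.

The compounds shown contain only a single change at this place, so they do not tell whether the trend goes on with a longer chain such as propyl, or holds for a branched group such as isopropyl or a chain ending in a hydroxyl group. On these data alone, compound 1 and compound 2 offer no number for comparison, so it also remains open whether ethyl would have a similar effect on other groups attached through the same ether link.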